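Sulfamoyl amine in place of the acetate ester

The compounds below may be only part of what the source reports. "The series", "measured", "known", "first", "only" and "open" are said of these compounds alone.

Compound 2 `CC(=O)OC[C@H]1CN(c2ccc(-n3cc(-c4ccccn4)cn3)c(F)c2)C(=O)O1`: 373000 nM
Compound 1 `O=C1O[C@@H](CN2CCC(O)CC2)CN1c1ccc(-n2cc(-c3ccccn3)cn2)c(F)c1`: 45900 nM

Compound 2 `CC(=O)OC[C@H]1CN(c2ccc(-n3cc(-c4ccccn4)cn3)c(F)c2)C(=O)O1` holds the higher of the two numbers in a physicochemical assay for solubility, read by HPLC, with a stated time of 24 h (on this read-out higher numbers stand for higher solubility and lower numbers for lower solubility), giving 373000 nM. Compound 1 `O=C1O[C@@H](CN2CCC(O)CC2)CN1c1ccc(-n2cc(-c3ccccn3)cn2)c(F)c1` gives 45900 nM in this assay, and the step of an 8.1-fold higher number from compound 1 to compound 2 (0.91 log units; beyond the scatter) is the only measured one. Compound 3 `CN(C)S(=O)(=O)NC[C@H]1CN(c2ccc(-n3cc(-c4ccccn4)cn3)c(F)c2)C(=O)O1` differs from compound 2 by (dimethylsulfamoyl)amino in place of acetoxy on a saturated chain carbon bound to a saturated ring carbon. For the measured compounds named here, the single measured step concerns a different group at the same place, so it gives no direct guide; no measured step bears on this change. The account therefore expects for compound 3 a step of a 1.1-fold higher number from compound 2 to compound 3 (0.03 log units; within the scatter) that is small, with no firm direction. Compound 3 is estimated at 400000 nM in this assay, within a range from 120000 nM to 1200000 nM.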

Compound 3, solubility: 472000 nM
Beside the measured number, compound 3's estimate is 1.2-fold (0.07 log units) below it; the measured number falls inside the stated range.
By their numbers in this assay, from the lowest: compound 1; then compounds 2 and 3 (each within the scatter of the next).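

At this saturated chain carbon bound to a saturated ring carbon, putting (dimethylsulfamoyl)amino in place of acetoxy leaves the reading in this assay within the usual scatter, with a 1.3-fold higher number from compound 2 to compound 3 (0.10 log units; within the scatter), so these two different groups cannot be told apart here. Set against 4-hydroxypiperidin-1-yl, the same group gives a 10-fold higher number from compound 1 to compound 3 (1.01 log units; beyond the scatter), so compound 1 now stands apart from two different groups at this place, not from acetoxy alone. Nothing available accounts for these numbers.

The compounds shown leave open whether a plain amine or a carboxylic acid at this place would read with compound 1 or with compound 2 and compound 3. They also leave open whether the gap belongs to 4-hydroxypiperidin-1-yl alone or would recur with another ring, such as morpholin-4-yl.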